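This account rests on a few compounds, and the source may have more. Where it says the series, first, only, none or still open, it means among the compounds named here.

Measured compounds:
compound 1, `COc1cc(-c2nn(-c3cccc(NC(=O)c4cccc(C(F)(F)F)c4)c3)cc2-c2ccncc2)ccc1Cl`, 1760 nM in a functional assay on DU-145 cells (Homo sapiens) for inhibition, read by sulforhodamine B assay, with a stated time of 48 h; on this read-out lower numbers stand for stronger inhibition of growth and higher numbers for weaker inhibition of growth
compound 2, `O=C(Nc1cccc(-n2cc(-c3ccncc3)c(-c3ccc(Cl)c(O)c3)n2)c1)Nc1cc(C(F)(F)F)cc(C(F)(F)F)c1`, 1250 nM
compound 3, `COc1cc(-c2nn(-c3cccc(NC(=O)Nc4cccc(C(F)(F)F)c4)c3)cc2-c2ccncc2)ccc1Cl`, 1670 nM

All three numbers lie within the usual scatter of one another, so compound 3 is not set apart from compound 1 or from compound 2 on this read-out. Compound 4, `COc1cc(-c2nn(-c3cccc(NC(=O)c4ccccc4)c3)cc2-c2ccncc2)ccc1Cl`, has not yet been measured. It differs from compound 3 in one place: phenyl in place of (3-(trifluoromethyl)phenyl)amino on a carbonyl carbon.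

For the measured compounds named here, one measured step bears on this change. From compound 1 to compound 3 the (3-(trifluoromethyl)phenyl)amino group replaced the 3-(trifluoromethyl)phenyl group on the carbonyl carbon, and the result was a 1.1-fold lower number from compound 1 to compound 3 (0.02 log units; within the scatter). Going by the values given here, the move from compound 3 to compound 4 reverses that exchange and additionally drops the trifluoromethyl from the ring; the loss of that group is covered by no measured pair here. The expected step, a 1.3-fold higher number from compound 3 to compound 4 (0.12 log units; within the scatter), is therefore small and uncertain, with no clear direction beyond the scatter. Compound 4 is expected to give about 2200 nM, within a range from 900 nM to 5500 nM.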

Compound 4, concentration for 50% growth inhibition: 780 nM
Beside the measured number, compound 4's estimate is 2.8-fold (0.45 log units) above it; measured number outside the range, below it.
By their numbers in this assay, from the lowest: compounds 4, 2, 3 and 1 (each within the scatter of the next, the first and the last beyond it).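

In this assay, the trifluoromethyl group proves not to be needed for growth inhibition: hydrogen in its place on the aromatic carbon gives a 2.3-fold lower number from compound 1 to compound 4 (0.35 log units; beyond the scatter), the first change in one place among these compounds to pass the scatter, though only modestly. The step of a 2.1-fold lower number from compound 3 to compound 4 (0.33 log units; beyond the scatter) is of similar size and also beyond the scatter, whereas the exchange on the carbonyl carbon alone, a 1.1-fold lower number from compound 1 to compound 3 (0.02 log units; within the scatter), stays within it, so among these compounds the shift goes with the loss of the trifluoromethyl. No measurement shown here accounts for this shift.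

The compounds shown leave open whether a fluorine, a methoxy group, an amine or a carboxylic acid on that aromatic carbon would do better or worse than hydrogen. They also leave open whether losing the trifluoromethyl would have the same effect on compound 3 with the amino group kept.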